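Swapping an aminophenyl for a difluorophenyl on a shared core

A few compounds are considered here, and "the series" means these few. Any claim that something is new, unique, unknown or untested is made for them only; others in the source may bear on it.

Measured compounds:
compound 1 `N[C@]1(C(=O)O)[C@H]2[C@@H](C[C@H]1OCc1ccccc1)[C@]2(F)C(=O)O` — 7.14 nM
compound 2 `N[C@]1(C(=O)O)[C@H]2[C@@H](C[C@H]1OCCCc1ccccc1)[C@]2(F)C(=O)O` — 9.83 nM
compound 3 `Nc1cccc(CO[C@@H]2C[C@@H]3[C@H]([C@]2(N)C(=O)O)[C@@]3(F)C(=O)O)c1` — 15.4 nM

In an assay on CHO cells for binding affinity to metabotropic glutamate receptor 2 (Rattus norvegicus) (a higher number here means a weaker inhibitor, a lower number a stronger inhibitor), compound 3 gives the highest of the three numbers. Compound 2 sits nearest to it, and the step of a 1.6-fold higher number from compound 2 to compound 3 (0.19 log units; within the scatter) stays within the scatter, while the step of a 2.2-fold higher number from compound 1 to compound 3 (0.33 log units; beyond the scatter) is modest but beyond it. Compound 4 `N[C@]1(C(=O)O)[C@H]2[C@@H](C[C@H]1OCc1cc(F)ccc1F)[C@]2(F)C(=O)O` differs from compound 3 by one change: 2,5-difluorophenyl in place of 3-aminophenyl on a saturated chain carbon bound to an oxygen on a saturated carbon. Within the data shown here, only one measured step bears on this. The step of a 2.2-fold higher number from compound 1 to compound 3 (0.33 log units; beyond the scatter) shows that adding the amino group to the phenyl raised the number; compound 4 removes that amino group again, so a step back of similar size is expected, with no measured comparison covering the fluorines themselves. Compound 4 is therefore expected at 8 nM (range 4 nM to 18 nM), a step of a 1.9-fold lower number from compound 3 to compound 4 (0.28 log units; within the scatter).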

Compound 4, inhibition constant: 14.4 nM
Estimate against measurement, compound 4: 1.8-fold (0.26 log units) below; the range from low to high includes it.
By their numbers in this assay, from the lowest: compounds 1, 2, 4 and 3 (each within the scatter of the next, the first and the last beyond it).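

In this assay, the 2,5-difluorophenyl group, with no hydrogen-bond donor or acceptor, cannot be told apart at this position from the 3-aminophenyl group, which has one of each: a 1.1-fold lower number from compound 3 to compound 4 (0.03 log units; within the scatter). It also stays within the scatter of the phenethyl and unsubstituted phenyl groups, with a 1.5-fold higher number from compound 2 to compound 4 (0.17 log units; within the scatter) and a 2.0-fold higher number from compound 1 to compound 4 (0.30 log units; within the scatter). No evidence at hand accounts for this result. The compounds shown leave open what a single fluorine on the phenyl would give, and whether the two fluorines contribute equally. They also leave open whether a methoxy group or a carboxylic acid on that ring would move the number beyond the scatter.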